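Notes on compound 4: 3-bromophenyl in place of 4-bromophenyl

The source may hold more compounds than are shown below. What is called first, only, known or untested is meant among the compounds shown, and "the series" means these compounds.

Measured so far in a functional assay on COLO 205 cells (Homo sapiens) for cytotoxicity, read by MTT assay, with a stated time of 48 h; a lower number here means a stronger inhibitor, a higher number a weaker inhibitor:
compound 1, `Fc1ccc(Nc2nc(-c3cccc(F)c3)nc3ccc(F)cc23)cc1` — a limit only, compound 1 giving > 50000 nM.
compound 2, `Fc1cccc(-c2nc(Nc3ccccc3F)c3cc(F)ccc3n2)c1` — a limit only, compound 2 giving > 50000 nM.
compound 3, `Fc1cccc(-c2nc(Nc3ccc(Br)cc3)c3cc(F)ccc3n2)c1` — a limit only, compound 3 giving > 50000 nM.

Every value shown in this assay is a limit of the measurement and not a number; the three compounds all sit at the same one (the limit of > 50000 nM in this assay, at which 3 of the 3 values shown sit). Compound 3 therefore stands nowhere distinguishable from the other two. The steps among the measured compounds, a step that the two limits leave unreadable from compound 1 to compound 2, a step that the two limits leave unreadable from compound 1 to compound 3 and a step that the two limits leave unreadable from compound 2 to compound 3, cannot be read in size or direction, since both ends of each are limits.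

Compound 4, `Fc1cccc(-c2nc(Nc3cccc(Br)c3)c3cc(F)ccc3n2)c1`, differs from compound 3 by 3-bromophenyl in place of 4-bromophenyl on a nitrogen on an aromatic ring. Among the compounds with values here, none of the measured steps covers this particular change, and none of them yields a readable size, so there is no basis in the data for expecting a move in either direction in this assay.

Compound 4 is accordingly estimated in this assay at 50000 nM, with an expected range from 20000 nM to 150000 nM, most probably again reported as a limit. The expected step of a number no higher from compound 3 to compound 4 (the limit leaves the size open) is estimated as none readable beyond the scatter.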

Compound 4, half-maximal inhibitory concentration: > 50000 nM
Compound 4 gave a limit, no number; the forecaster's own chance of this, stated with the estimate: 85%; the middle value sits exactly at the limit.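

In this assay compound 4 gives > 50000 nM, a limit and not a number. No step linking compound 4 to compound 1, compound 2 or compound 3 can be read, because all four sit at one limit: the limit of > 50000 nM in this assay, at which 4 of the 4 values shown sit.

On these data alone, whether 4-fluorophenyl, 2-fluorophenyl, 4-bromophenyl and 3-bromophenyl on the nitrogen differ at all in this assay stays open.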